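A Single Fluoro Swap on Compound 2

The compounds below may be only part of what the source reports. "The series", "measured", "known", "first", "only" and "open" are said of these compounds alone.

Of the compounds shown here, three have been measured so far. In an in vivo ADME assay on the whole organism (strain BALB/c) for pharmacokinetics, with Mus musculus as the target, read by LC-MS, at a dose of 5 mg/kg by the oral route (on this read-out higher numbers stand for higher oral bioavailability and lower numbers for lower oral bioavailability), compound 1 (`CCCS(=O)(=O)c1ccc(C)c(C#Cc2cc(C#N)ccc2OCC(=O)O)c1`) stands at 24% and compound 2 (`CCCS(=O)(=O)c1cccc(C#Cc2cc(Cl)ccc2OCC(=O)O)c1`) at 37% while compound 3 (`CC(C)S(=O)(=O)c1ccc(Cl)c(C#Cc2cc(Cl)ccc2OCC(=O)O)c1`) stands at 64% so compound 2 holds the middle place of the three. Its gaps to both of the others lie beyond the usual scatter of repeated measurements.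

Compound 4 (`CCCS(=O)(=O)c1ccc(F)c(C#Cc2cc(Cl)ccc2OCC(=O)O)c1`) has no number yet. It differs from compound 2 in one place (fluoro in place of hydrogen on an aromatic carbon): fluoro in place of hydrogen on an aromatic carbon, ortho to a large group and para to a propylsulfonyl group.

Going by the values given here, no two measured compounds differ in only one place, so the data hold no direct measure of such a change. Compound 1 and compound 3 each differ from compound 2 in more than one place and offer only loose guidance. The estimated step of a number 6 percentage points higher from compound 2 to compound 4 (within the scatter) is small, leans upward and is expected to stay within the scatter. In this assay the estimate for compound 4 is 43% with an expected range from 26% to 62% across repeat measurements.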

Compound 4, oral bioavailability: 63%
Beside the measured number, compound 4's estimate is 20 percentage points below it, and the stated range ends below it.
By their numbers in this assay, from the lowest: compound 1; then compound 2; then compounds 4 and 3 (each within the scatter of the next).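

Going by these compounds alone, this is the first direct measure of a single change. In this assay, placing fluoro on this aromatic carbon, ortho to a large group and para to a propylsulfonyl group, gives a number 26 percentage points higher from compound 2 to compound 4 (beyond the scatter), so one added heavy atom at this position is enough to produce a step larger than repeat measurements would normally show. The data shown contain no measurement that accounts for this rise.

Within the data shown here, with only one such pair, it remains open whether fluoro would give a similar step on a compound that differs elsewhere on the shared core. It is also unknown how this position would respond to a different group, such as a methoxy group or an amine. Neither appears there in the compounds shown.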